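This account rests on a few compounds, and the source may have more. Where it says the series, first, only, none or still open, it means among the compounds named here.

Compound 1 `Cc1oc(=O)oc1COC(=O)c1cccc(NC(=O)[C@@H]2C[C@H](SC3=C(C(=O)O)N4C(=O)[C@H]([C@@H](C)O)[C@H]4[C@H]3C)CN2)c1` was examined in an ADME assay for metabolic stability, read by LC-MS, with a stated time of 3 h, at pH 6.5, tested at 50 uM; on this read-out lower numbers stand for a less stable compound and higher numbers for a more stable compound. In this assay compound 1 gives > 95%, which is a limit of the assay rather than a measured number. Compound 2 `Cc1oc(=O)oc1COC(=O)N1C[C@@H]2C[C@H]1C(=O)Nc1cccc(c1)C(=O)OC/C=C/COC(=O)C1=C(S2)[C@H](C)[C@@H]2[C@@H]([C@@H](C)O)C(=O)N12` gives > 95% in this assay, again only a limit. For the measured compounds named here, both values sit at the limit of > 95% in this assay, at which 2 of the 2 values shown sit, so no step between measured compounds can be read off. Compound 3 `CC(C)OC(=O)c1cccc(NC(=O)[C@@H]2C[C@H](SC3=C(C(=O)O)N4C(=O)[C@H]([C@@H](C)O)[C@H]4[C@H]3C)CN2)c1` differs from compound 1 by a group of 3 heavy atoms (3 carbon; no ring) in place of a group of 8 heavy atoms (5 carbon, 3 oxygen; one five-membered aromatic ring with 2 hetero atoms), on an oxygen next to a carbonyl group. With only limits shown, no step beyond the usual scatter is expected, and the estimated step from compound 1 to compound 3 is a number no higher from compound 1 to compound 3 (the limit leaves the size open). Compound 3 is therefore expected to give about 95% in this assay, within 85% to 99%.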

Compound 3, percent of the compound remaining: > 95%
Compound 3 gave a limit, no number; the forecaster's own chance of this, stated with the estimate: 70%; the middle value sits exactly at the limit.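

Compound 1 and compound 3 both give a limit of the assay rather than a number, so no step between them can be read: the limit of > 95% in this assay, at which 3 of the 3 values shown sit.

As far as these compounds go, whether isopropyl in place of the larger group changes the stability of compound 3 at all stays open.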